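Losing a Methyl on the Shared Core

The source may hold more compounds than are shown below. What is called first, only, known or untested is meant among the compounds shown, and "the series" means these compounds.

Of the compounds shown here, three have so far been tested in a functional assay on SK-MEL-5 cells (Homo sapiens); a higher number here means a weaker inhibitor of growth, a lower number a stronger inhibitor of growth. Compound 1 `COc1ccc(-c2cc(O)c3cccnc3n2)cc1` gives 34700 nM. Compound 3 `COc1ccc(-c2cc(O)c3cc(C)cnc3n2)cc1` gives 3720 nM, and compound 2 `COc1cccc(-c2cc(O)c3c(C)cc(C)nc3n2)c1` gives 288 nM, the lowest of the three. Compound 2 and compound 3 differ in more than one place, and the difference between their cores is not broken down here.

Compound 3 and compound 1 differ only by hydrogen in place of methyl on an aromatic carbon. This single change produced a 9.3-fold higher number from compound 3 to compound 1 (0.97 log units; beyond the scatter), so the methyl on the core of compound 3 matters for growth inhibition.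

Compound 4 `COc1cccc(-c2cc(O)c3c(C)ccnc3n2)c1`, not yet measured, is related to compound 2 by hydrogen in place of methyl on an aromatic carbon. This is the same kind of change, though the place is not identical: in compound 2 the methyl sits next to the ring nitrogen and meta to a methyl group, whereas in compound 3 it sits two atoms from the ring nitrogen.

Because compound 3 showed a 9.3-fold higher number from compound 3 to compound 1 (0.97 log units; beyond the scatter) when its methyl was removed, a weakening of similar size is expected here, namely a 5.2-fold higher number from compound 2 to compound 4 (0.72 log units; beyond the scatter). Compound 4 is therefore estimated at 1500 nM, within a range of 400 nM to 6000 nM.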

Compound 4, concentration for 50% growth inhibition: 22.4 nM
The estimate for compound 4 lay 67-fold (1.83 log units) above the measured number, and the stated range ends above it.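

Removing the methyl from the core did not weaken growth inhibition here. In this assay, the change instead gave a 13-fold lower number from compound 2 to compound 4 (1.11 log units; beyond the scatter). Set beside the earlier step, the same replacement of methyl by hydrogen moved the number in opposite directions: the same change on two cores in this assay, a 9.3-fold higher number (0.97 log units; beyond the scatter) from compound 3 to compound 1 and a 13-fold lower number (1.11 log units; beyond the scatter) from compound 2 to compound 4, 120-fold (2.08 log units) apart, beyond the scatter of two such steps. This shows that, in this series, the effect of this change on one core cannot simply be carried over to another, but it does not show why, since the methyl leaves from a different place in each pair and the two pairs also differ elsewhere in their structures.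

The compounds shown leave open whether the same reversal would appear on other cores, and how much the methyl that remains on compound 4 contributes. They also leave open what would happen if an ethyl chain or an amine stood on the aromatic carbon next to the ring nitrogen, where compound 4 carries only hydrogen.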